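The compounds below may be only part of what the source reports. "The series", "measured", "known", "first", "only" and "open" are said of these compounds alone.

In a functional assay on A549 cells (Homo sapiens) for cytotoxicity, read by MTT assay, with a stated time of 72 h (a lower number here means a stronger inhibitor, a higher number a weaker inhibitor), compound 1 (`O=C(Nc1nnc(-c2cccc(O)c2O)s1)c1ccc(Cl)cc1`) gives 9500 nM as its half-maximal inhibitory concentration. Compound 2 (`O=C(Nc1nnc(-c2ccc(O)c(O)c2)s1)C1CCCCC1`) gives 16300 nM in this assay as well, so the two values lie within the scatter of each other and neither can be set apart from the other. Compound 3 (`CC(=O)Nc1nnc(-c2cccc(O)c2O)s1`) keeps the core of compound 1 and carries methyl in place of 4-chlorophenyl on a carbonyl carbon. Among the compounds with values here, no two measured compounds differ in one place only, so the data give no direct measure of this change. In this assay a moderate step toward a higher number, meaning a weaker inhibitor, is expected, somewhat beyond the scatter, though little anchors its size. That expectation starts from compound 1 at 9500 nM and from the size of the group that leaves. The estimate amounts to an expected step (a 3.2-fold higher number from compound 1 to compound 3 (0.50 log units; beyond the scatter)) for this single change. For compound 3 the estimated value is 30000 nM with an expected range from 11000 nM to 80000 nM as the likely span.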

Compound 3, half-maximal inhibitory concentration: 200000 nM
Compound 3: the middle estimate sits 6.7-fold (0.82 log units) below what was measured; measured number outside the range, above it.
By their numbers in this assay, from the lowest: compounds 1 and 2 (each within the scatter of the next); then compound 3.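

Within the data shown here, replacing 4-chlorophenyl with methyl on a carbonyl carbon gives a 21-fold higher number from compound 1 to compound 3 (1.32 log units; beyond the scatter) in this assay and is the first change here that can be read in one place. It shows that, on the core of compound 1, this position is not indifferent to the group it carries. The step is large, yet no measurement shown gives a reason for it.

The compounds shown leave open whether the ring itself or the chlorine on it accounts for the difference, a question that phenyl without the chlorine on the same carbonyl carbon would address. They also leave open whether a longer chain such as butyl, or an amine in that place, would recover part of the step or none of it.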